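Swapping the sulfonyl partner in a prostaglandin D2 receptor 2 antagonist series

The compounds below may be only part of what the source reports. "The series", "measured", "known", "first", "only" and "open" are said of these compounds alone.

Measured compounds:
Compound 1, `Cc1c(Cc2ccc(C(=O)O)cc2S(=O)(=O)c2ccccc2)c2c(n1CC(=O)O)CCNC2=O`: 19 nM
Compound 2, `COc1cccc(S(=O)(=O)c2ccccc2)c1Cc1c2c(n(CC(=O)O)c1C)CCNC2=O`: 4500 nM
Compound 3, `COc1cccc(S(=O)(=O)c2ccccc2Cc2c3c(n(CC(=O)O)c2C)CCNC3=O)c1`: 12 nM

Of the compounds shown here, three sharing one core have been tested in a functional assay on CHO.K1 cells for antagonist activity at prostaglandin D2 receptor 2 (Homo sapiens), read by GTPgammaS binding, with a stated time of 1 h; a higher number here means a weaker inhibitor, a lower number a stronger inhibitor. Compound 3 gives the lowest number of the three with 12 nM. Its nearest neighbour is compound 1, whose 19 nM lies within the scatter of compound 3, so the two cannot be ordered. Compound 2, with 4500 nM, stands far beyond the scatter from compound 3 and is the weakest inhibitor of the set.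

Compound 4, `Cc1c(Cc2ccccc2S(=O)(=O)N(C)Cc2ccccc2)c2c(n1CC(=O)O)CCNC2=O`, has not yet been measured in this assay. It differs from compound 3 in one place:

benzyl(methyl)amino in place of 3-methoxyphenyl on a sulfonyl sulfur

Within the data shown here, no step between two measured compounds matches this change, so there is no direct precedent for how a benzyl(methyl)amino group on the sulfonyl sulfur behaves in this assay. The three measured values show that the sulfonyl region tolerates some variation while also admitting a large loss, as compound 2 shows with 4500 nM. Compound 4 is therefore expected to lose some potency relative to compound 3, with a step of a 5.0-fold higher number from compound 3 to compound 4 (0.70 log units; beyond the scatter) that may or may not exceed the scatter. The estimate for compound 4 in this assay is 60 nM, with a range from 8 nM to 500 nM.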

Compound 4, half-maximal inhibitory concentration: 26 nM
For compound 4 the middle estimate is 2.3-fold (0.36 log units) above the measured one; low and high end bracket the measured number.
By their numbers in this assay, from the lowest: compounds 3, 1 and 4 (each within the scatter of the next, the first and the last beyond it); then compound 2.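

In this assay, putting benzyl(methyl)amino in place of 3-methoxyphenyl on a sulfonyl sulfur gives a 2.2-fold higher number from compound 3 to compound 4 (0.34 log units; beyond the scatter), so this position keeps most of its potency when the group on sulfur is attached through nitrogen rather than directly through an aromatic ring. The change is tolerated even though the group that enters has one more heavy atom than the one that leaves, contains nitrogen instead of oxygen and has no hydrogen-bond acceptor where 3-methoxyphenyl has one, while the six-membered aromatic ring of carbon is kept in both. No supporting measurement is available to account for this modest step, so the result stands as an observation about this single pair of compounds.

The compounds shown leave open which part of benzyl(methyl)amino matters, since this one change alters the link to the sulfur, the methyl group and the benzyl group together. A simple benzylamino group, a dimethylamino group or a piperidine on the same sulfonyl sulfur would help separate these contributions, including whether an aromatic ring is needed in this group at all.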